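From Isopropyl to Phenyl on a Shared Core

This account rests on a few compounds, and the source may have more. Where it says the series, first, only, none or still open, it means among the compounds named here.

Compound 2 `COC(=O)c1c[nH]c2ccc(C(C)C)cc2c1=O` reads > 20000 nM in an ADME assay on J774 cells (Mus musculus) for cytotoxicity (on this read-out lower numbers stand for an effect already at smaller amounts and higher numbers for an effect only at larger amounts of compound), which is a limit of the assay and not a number. Compound 3 `COC(=O)c1c[nH]c2ccc(-c3ccccc3)cc2c1=O` carries phenyl in place of isopropyl on an aromatic carbon. Among the measured compounds shown here, no measured step shows what such a change does. Compound 1 `COC(=O)c1c[nH]c2ccc(OCCCc3ccccc3)cc2c1=O`, with the same core, gives 17100 nM in this assay, so a reading of similar size seems likely for compound 3. The expected change is small and toward lower numbers, an at least 1.1-fold lower number from compound 2 to compound 3 (0.07 log units; that floor lies within the scatter). For compound 3 the estimated value is 17000 nM, with an expected range of 7000 nM to 35000 nM.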

Compound 3, half-maximal effective concentration: > 20000 nM
Compound 3 ended at the assay's limit; the forecaster's own chance of this, stated with the estimate: 45%; middle value at least 1.1-fold (0.07 log units) away from the limit.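

Among the compounds shown here, no step from compound 2 to compound 3 can be read in this assay, because both values are limits of the assay: the limit of > 20000 nM in this assay, at which 2 of the 3 values shown sit. As far as these compounds go, whether phenyl in place of isopropyl on an aromatic carbon changes the read-out at all stays open.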